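Ethylcarbamoyl to carboxy on the core of compound 1

The source may report more compounds than this note shows. Statements on the series, on what has been measured and on what is new or still open speak of the compounds shown alone.

Compound 1 `CCNC(=O)c1sc(-c2ccccc2)nc1O` returns in an assay on HEK293 cells for inhibition of transient receptor potential cation channel subfamily M member 8 (Homo sapiens), read by FLIPR, with stated times of 5 min and 3 min (a lower number here means a stronger inhibitor, a higher number a weaker inhibitor), no number but a limit, > 100000 nM; it sits at the limit of > 100000 nM in this assay, at which 1 of the 3 values shown sits. The two measured compounds that do give numbers differ from it in more than one place. In this assay compound 2 `O=C(c1sc(-c2cccc(F)c2)nc1O)N1CCCCO1` gives 167 nM. In this assay compound 3 `CCN(C(=O)/C=C/c1cccc([N+](=O)[O-])c1)c1ccccc1` gives 575 nM. The step to compound 4 `O=C(O)c1sc(-c2ccccc2)nc1O` is hydroxy in place of ethylamino on a carbonyl carbon. For the measured compounds named here, no measured pair shows this change, so the expectation rests on compound 1 alone, which already reaches the limit. The step of a number no higher from compound 1 to compound 4 (the limit leaves the size open) is expected to be none beyond the scatter. Compound 4 is estimated at 100000 nM, between 30000 nM and 300000 nM, and is most likely to be reported as a limit again.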

Compound 4, half-maximal inhibitory concentration: > 100000 nM
Compound 4 was reported as a limit (the forecaster's own chance of this, stated with the estimate: 85%); the middle value sits exactly at the limit.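

Compound 1 and compound 4 are both reported only as limits, so no step between them can be read: the limit of > 100000 nM in this assay, at which 2 of the 4 values shown sit.

The compounds shown leave open how far ethylamino and hydroxy on this carbonyl carbon differ in inhibition.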